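Moving the chlorine on the benzyl group of compound 2

The source may report more compounds than this note shows. Statements on the series, on what has been measured and on what is new or still open speak of the compounds shown alone.

The series shares one core, seen in compound 1 `O=C1/C(=C/c2ccccc2F)CN(Cc2cn(Cc3ccc(F)cc3)nn2)C/C1=C\c1ccccc1F`, which in a functional assay on MCF7 cells (Homo sapiens) for cytotoxicity, read by MTT assay, with a stated time of 24 h (on this read-out lower numbers stand for stronger inhibition and higher numbers for weaker inhibition), gives 6000 nM. Compound 2 `Cc1ccc(/C=C2\CN(Cc3cn(Cc4cccc(Cl)c4)nn3)C/C(=C\c3ccc(C)cc3)C2=O)cc1` gives 10000 nM, and compound 3 `O=C1/C(=C/c2ccccc2F)CN(Cc2cn(Cc3ccccc3Cl)nn2)C/C1=C\c1ccccc1F` gives 10000 nM. Compound 2 thus shows the same number as compound 3, and these two hold the highest numbers of the three; the gap from compound 2 to compound 1 is within the scatter. Compound 4 `Cc1ccc(/C=C2\CN(Cc3cn(Cc4ccccc4Cl)nn3)C/C(=C\c3ccc(C)cc3)C2=O)cc1` is not yet measured. It differs from compound 2 by 2-chlorophenyl in place of 3-chlorophenyl on a saturated chain carbon bound to an aromatic nitrogen.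

Going by the values given here, one measured step bears on this change, since it brings in the same 2-chlorophenyl at the same place: a 1.7-fold higher number from compound 1 to compound 3 (0.22 log units; within the scatter). Among the compounds with values here, that step stayed within the scatter, and no measured pair shows 3-chlorophenyl against 2-chlorophenyl directly. Compound 4 is therefore expected to stay close to compound 2, with a step of no change at the digits printed from compound 2 to compound 4 (within the scatter) that is not expected to go beyond the scatter. Compound 4 is estimated at 10000 nM, in a range from 5000 nM to 20000 nM.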

Compound 4, half-maximal inhibitory concentration: 66700 nM
For compound 4 the middle estimate is 6.7-fold (0.82 log units) below the measured one; the whole stated range lies below it.
By their numbers in this assay, from the lowest: compounds 1, 2 and 3 (each within the scatter of the next); then compound 4.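

In this assay the position of the chlorine on the benzyl group proves to matter on the core of compound 2, where a 6.7-fold higher number from compound 2 to compound 4 (0.82 log units; beyond the scatter) goes beyond the scatter even though the two compounds hold the same atoms, joined differently. Going by these compounds alone, the only earlier step bringing in 2-chlorophenyl at this place, a 1.7-fold higher number from compound 1 to compound 3 (0.22 log units; within the scatter) and stayed within the scatter, so that step alone did not reveal this sensitivity, and it started from 4-fluorophenyl in compounds with different outer groups on the shared core. No evidence here accounts for the size of the new step.

As far as these compounds go, it remains open whether moving the chlorine in the same way has a comparable effect on the core of compound 1. Also open, from the compounds shown here alone, is whether 4-chlorophenyl or 2-methoxyphenyl at this place would track compound 2 or compound 4.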